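The compounds below may be only part of what the source reports. "The series", "measured", "known", "first", "only" and "open" are said of these compounds alone.

For the measured compounds named here, compound 1 `COc1ccc(C=c2s/c(=C3\C(=O)Nc4cc(F)ccc43)n(CCN(C)C)c2=O)cc1` is one of three compounds measured in a functional assay on HT-29 cells (Homo sapiens) for inhibition, read by MTT assay, with a stated time of 72 h; a higher number here means a weaker inhibitor, a lower number a stronger inhibitor. Its number there is the second highest of the three: compound 1 gives 2300 nM. Compound 2 `COc1cc(C=c2s/c(=C3\C(=O)Nc4ccc(F)cc43)n(CCN(C)C)c2=O)cc(OC)c1OC` gives 2530 nM in this assay, a value that sits within the usual scatter of the number for compound 1, so the two are not separated. Compound 3 `Cc1ccc2c(c1)/C(=c1/sc(=Cc3ccc(C=O)c(C=O)c3)c(=O)n1CCN(C)C)C(=O)N2` gives 1030 nM in this assay, a lower number than that of compound 1 by more than the scatter, which marks compound 3 as the stronger inhibitor of the three on these numbers alone.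

Compound 4 `CN(C)CCn1c(=O)c(=Cc2ccc(F)c(F)c2)s/c1=C1\C(=O)Nc2cc(F)ccc21` has not yet been measured in this assay. It differs from compound 1 in one place: 3,4-difluorophenyl in place of 4-methoxyphenyl on a double-bonded chain carbon bound to an aromatic carbon. Going by the values given here, no pair of measured compounds differing only at this place is available, so nothing in the measured set speaks directly to the size or direction of this step.

Among the compounds with values here, the account therefore expects, for the step from compound 1 to compound 4, a change of a 1.2-fold lower number from compound 1 to compound 4 (0.08 log units; within the scatter) in this assay, that is, no step clearly beyond the scatter in either direction. Compound 4 is estimated to give 1900 nM in this assay, with a likely range from 600 nM to 6000 nM.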

Compound 4, half-maximal inhibitory concentration: 12100 nM
Compound 4: middle estimate off by 6.4-fold (0.80 log units), on the low side; the measured number lies above the stated range.
By their numbers in this assay, from the lowest: compound 3; then compounds 1 and 2 (each within the scatter of the next); then compound 4.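

For the compounds shown here, the step from 4-methoxyphenyl to 3,4-difluorophenyl on a double-bonded chain carbon bound to an aromatic carbon is the first comparison here between compounds that differ in one place, and in this assay it reads as a 5.3-fold higher number from compound 1 to compound 4 (0.72 log units; beyond the scatter) and so marks compound 4 as the weaker inhibitor. This position is therefore not indifferent to what it carries: with the rest of compound 1 unchanged, exchanging one group for another of the same heavy-atom count, each a six-membered aromatic ring of carbon only, is enough to move the number beyond the scatter. Nothing available bears on what lies behind the size or direction of this step.

A single step cannot tell whether the weaker inhibition goes with losing the methoxy group or with gaining the two fluorines, and a plain phenyl, a 4-fluorophenyl or a 4-hydroxyphenyl at the same place would help to separate these readings. As far as these compounds go, it also remains open whether this exchange would give a step of similar size on another substitution of the shared core, since it is seen here on one background only.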